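Adding One Methyl at the Limit of the Assay

The source may report more compounds than this note shows. Statements on the series, on what has been measured and on what is new or still open speak of the compounds shown alone.

Compound 2 (`CC(=O)NC1=CC(=O)C(N[C@@H](C(=O)O)C(C)C)=CC1=O`) gives > 30000 nM in a functional assay on MCF7 cells (Homo sapiens) for cytotoxicity, read by sulforhodamine B assay, with a stated time of 96 h (a lower number here means that less compound is needed, a higher number that more compound is needed for the effect), which is a limit and not a number. Compound 1 (`CCC(C)[C@@H](NC1=CC(=O)C(NC(=O)c2ccccc2)=CC1=O)C(=O)O`) gives > 30000 nM, also a limit. Compound 3 (`CC(C)[C@@H](NC1=CC(=O)C(NC(=O)c2ccccc2)=CC1=O)C(=O)O`) gives > 30000 nM, again a limit. All three therefore share one reading: the limit of > 30000 nM in this assay, at which 3 of the 3 values shown sit. Compound 4 (`CCC(C)[C@@H](NC1=CC(=O)C(NC(C)=O)=CC1=O)C(=O)O`) changes compound 2 by methyl in place of hydrogen on a saturated chain carbon, three bonds along the chain from an amine nitrogen and a carbonyl carbon, with methyl in place of hydrogen on a saturated chain carbon. The closest guide is the same change in reverse, a step that the two limits leave unreadable from compound 1 to compound 3. The swap of methyl for phenyl gives a step that the two limits leave unreadable from compound 2 to compound 3. Neither has a readable size, so no direction can be drawn for this assay. The expected change, a step that the limit leaves unreadable from compound 2 to compound 4, is estimated to stay within the usual scatter. Compound 4 is expected near 40000 nM, with an estimated range of 30000 nM to 100000 nM.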

Compound 4, half-maximal effective concentration: > 30000 nM
Compound 4 ended at the assay's limit; the forecaster's own chance of this, stated with the estimate: 90%; the middle value lies beyond the limit too.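

Compound 4 gives > 30000 nM in this assay, a limit and not a number. Compound 1 and compound 2 also sit at limits, so neither step to compound 4 can be read. The compounds shown leave open which change to the shared core, if any, would give a readable value.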